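Urea-linked Anilines on a Shared Core: Ethyl for Methoxy

A few compounds are considered here, and "the series" means these few. Any claim that something is new, unique, unknown or untested is made for them only; others in the source may bear on it.

Measured compounds:
compound 1, `Cc1nc2ccccc2c(=O)n1NC(=O)Nc1ccc(Cl)cc1`, 48%
compound 2, `COc1ccc(NC(=O)Nn2c(C)nc3ccccc3c2=O)cc1`, 42%

In a functional assay on the whole organism for inhibition, with Mus musculus as the target, with a stated time of 1 h, at a dose of 100 mg/kg by the intraperitoneal route (a lower number here means less inhibition, a higher number more inhibition at the dose given (going by the name of the read-out)), compound 1 gives 48%, and compound 2 gives 42%. For the measured compounds named here, the single measured step, a number 6 percentage points lower from compound 1 to compound 2 (within the scatter), leaves the two numbers within the scatter of each other, so compound 2 stands as the lower of the two numbers without a real difference from compound 1.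

Compound 3, `CCc1ccc(NC(=O)Nn2c(C)nc3ccccc3c2=O)cc1`, differs from compound 2 by ethyl in place of methoxy on an aromatic carbon. Going by the values given here, no measured step exchanges ethyl for methoxy, so the only bearing this series has is that the one change made so far at the same place, a number 6 percentage points lower from compound 1 to compound 2 (within the scatter), stayed within the scatter. Compound 3 is therefore expected to stay close to compound 2, with a step of a number 3 percentage points higher from compound 2 to compound 3 (within the scatter) that carries no direction beyond the scatter. The estimate for compound 3 is 45%, in a range from 25% to 65%.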

Compound 3, a percentage reported as inhibition, in the whole organism at one dose (the size of the read-out at that dose, not a potency): 53%
For compound 3 the middle estimate is 8 percentage points below the measured one, within the range that was stated.
By their numbers in this assay, from the lowest: compounds 2, 1 and 3 (each within the scatter of the next, the first and the last beyond it).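

In this assay, for the compounds shown here, the exchange of methoxy for ethyl, on an aromatic carbon para to a large group, gives the first step that lies beyond the scatter (a number 11 percentage points higher from compound 2 to compound 3 (beyond the scatter)). Ethyl in place of chloro at the same place stays within the scatter (a number 5 percentage points higher from compound 1 to compound 3 (within the scatter)), so this position has now answered to one of the changes made there, while chloro and ethyl cannot be told apart. Nothing given here accounts for the step from methoxy to ethyl.

The compounds shown leave open whether an amine or a carboxylic acid at this place would stay level with these numbers or move beyond the scatter. They also leave open whether a longer chain in place of ethyl would extend the step from methoxy to ethyl.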